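This account rests on a few compounds, and the source may have more. Where it says the series, first, only, none or still open, it means among the compounds named here.

Compound 1 `CCCCCc1ccc(-c2cn(C[C@H](O)[C@H]3OC(=O)C(OCc4ccccc4)=C3OCc3ccccc3)nn2)cc1`: 12200 nM
Compound 2 `Cc1ccc(-c2cn(C[C@H](O)[C@H]3OC(=O)C(OCc4ccccc4)=C3OCc3ccccc3)nn2)cc1`: > 100000 nM

In a functional assay on SW-620 cells (Homo sapiens) for antiproliferative activity, read by MTT assay, with a stated time of 72 h (a higher number here means a weaker inhibitor, a lower number a stronger inhibitor), compound 2 gives > 100000 nM, which is a limit and not a number.

Compound 3 `O=C1O[C@H]([C@@H](O)Cn2cc(CCCCl)nn2)C(OCc2ccccc2)=C1OCc1ccccc1` carries one change: 3-chloropropyl in place of 4-methylphenyl on an aromatic carbon. In words, 3-chloropropyl stands in place of 4-methylphenyl on an aromatic carbon. Within the data shown here, only one measured step bears on this, an at least 8.1-fold higher number from compound 1 to compound 2 (0.91 log units; beyond the scatter), and it altered the group that now leaves. That step shows that a change in this group can move the number, but it gives no direction for this swap. A modest fall in this assay is expected, though compound 3 may also reach the limit. The expected step is an at least 2.0-fold lower number from compound 2 to compound 3 (0.30 log units; that floor lies within the scatter). For compound 3 the estimate is 50000 nM, with an expected range of 15000 nM to 100000 nM.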

Compound 3, half-maximal inhibitory concentration: 68500 nM
Compound 3: the middle estimate sits 1.4-fold (0.14 log units) below what was measured, within the range that was stated.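

In this assay, a group with no ring on this aromatic carbon still gives a measured number, but 3-chloropropyl does not match 4-pentylphenyl: the swap gives a 5.6-fold higher number from compound 1 to compound 3 (0.75 log units; beyond the scatter). Against 4-methylphenyl, the swap reads as an at least 1.4-fold lower number from compound 2 to compound 3 (0.16 log units; that floor lies within the scatter). The true size of that step stays open because compound 2 sits at a limit: the limit of > 100000 nM in this assay, at which 1 of the 3 values shown sits.

As far as these compounds go, what a pentyl chain or an aminopropyl group would give in this place remains open. So does whether the chlorine or the chain itself accounts for the value of compound 3.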